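The source may report more compounds than this note shows. Statements on the series, on what has been measured and on what is new or still open speak of the compounds shown alone.

Compound 1 `COc1ccc2[nH]c(C)c(Cc3ccccc3)c(=O)c2c1` and compound 2 `Cc1[nH]c2ccc(Cl)cc2c(=O)c1Cc1ccccc1` share one core and differ by a single change: chloro in place of methoxy on an aromatic carbon. In an ADME assay on J774 cells (Mus musculus) for cytotoxicity (on this read-out lower numbers stand for an effect already at smaller amounts and higher numbers for an effect only at larger amounts of compound), compound 1 reaches only the limit of the assay, > 23700 nM. In this assay compound 2 likewise reaches only a limit, > 35200 nM. The step that the two limits leave unreadable from compound 1 to compound 2 cannot be read because the limit of > 23700 nM in this assay, at which 1 of the 3 values shown sits, and the limit of > 35200 nM in this assay, at which 1 of the 3 values shown sits, are both limits of the assay. Compound 3 `COc1ccc2c(=O)c(Cc3ccccc3)c(C)[nH]c2c1` is built from the same atoms as compound 1, joined differently; the difference between the two cores is not broken down here. In this assay compound 3 also gives only a limit, > 35800 nM. Compound 4 `Cc1[nH]c2cc(Cl)ccc2c(=O)c1Cc1ccccc1` has not yet been measured; it differs from compound 3 by the same change, (chloro in place of methoxy on an aromatic carbon). The earlier step gave no readable size, and every measured value sits at a limit, as the limit of > 35800 nM in this assay, at which 1 of the 3 values shown sits, shows for the third. Compound 4 is therefore expected to give about 40000 nM in this assay, estimated between 20000 nM and 100000 nM. The expected step is a step that the limit leaves unreadable from compound 3 to compound 4, most likely reported again only as a limit.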

Compound 4, half-maximal effective concentration: > 35200 nM
Compound 4 was reported as a limit; the forecaster's own chance of this, stated with the estimate: 85%; the middle value does not contradict the limit.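

No step can be read between compound 3 and compound 4, since in this assay both give only limits of the assay. The compounds shown leave open at what concentration compound 1, compound 2, compound 3 or compound 4 would reach the half-maximal effect in this assay, and whether chloro in place of methoxy changes that concentration at all.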